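The source may report more compounds than this note shows. Statements on the series, on what has been measured and on what is new or still open speak of the compounds shown alone.

Measured in a functional assay on A-375 cells (Homo sapiens) for activation, with a stated time of 3 days; on this read-out higher numbers stand for an effect only at larger amounts of compound and lower numbers for an effect already at smaller amounts:
compound 1 `O=C(Nc1ccc(-c2ncc[nH]2)cc1)C1CCCN(Cc2ccc(F)c(F)c2)C1`: 8000 nM
compound 2 `O=C(Nc1ccc(-c2ccn[nH]2)cc1)C1CCCN(Cc2ccc(F)c(F)c2)C1`: 580 nM
compound 3 `O=C(Nc1ccc(-c2cccs2)cc1)C1CCCN(Cc2ccc(F)c(F)c2)C1`: 530 nM

These three compounds share one core and differ only in the five-membered aromatic ring on the six-membered one. Compound 3 sits level with compound 2, as a 1.1-fold lower number from compound 2 to compound 3 (0.04 log units; within the scatter) shows, and both lie far under compound 1. The next change gives compound 4 `O=C(Nc1ccc(-c2cc[nH]c2)cc1)C1CCCN(Cc2ccc(F)c(F)c2)C1`, with 1H-pyrrol-3-yl in place of thiophen-2-yl on an aromatic carbon.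

Among the compounds with values here, three measured steps bear on this swap, since each exchanges one such ring for another. Two are large: a 14-fold lower number from compound 1 to compound 2 (1.14 log units; beyond the scatter) and a 15-fold lower number from compound 1 to compound 3 (1.18 log units; beyond the scatter). The third, a 1.1-fold lower number from compound 2 to compound 3 (0.04 log units; within the scatter), is small. So two quite different rings can give the same number, while compound 1 stands as the warning that a single ring exchange can cost a great deal. Compound 4 has not been tested, and its ring matches none of the three exactly. The likeliest outcome is therefore no real change, with more room upward than downward. The expected step is a 1.2-fold higher number from compound 3 to compound 4 (0.09 log units; within the scatter), which would stay within the usual scatter. For compound 4 the estimated value is 650 nM, with an expected range from 220 nM to 2800 nM.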

Compound 4, half-maximal effective concentration: 2610 nM
Beside the measured number, compound 4's estimate is 4.0-fold (0.60 log units) below it; the measured number falls inside the stated range.
By their numbers in this assay, from the lowest: compounds 3 and 2 (each within the scatter of the next); then compound 4; then compound 1.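

In this assay the ring at this position now gives three separate levels rather than two: a 4.9-fold higher number from compound 3 to compound 4 (0.69 log units; beyond the scatter) and a 4.5-fold higher number from compound 2 to compound 4 (0.65 log units; beyond the scatter) set the 1H-pyrrol-3-yl ring apart from the pair that matched, while a 3.1-fold lower number from compound 1 to compound 4 (0.49 log units; beyond the scatter) keeps it clear of the 1H-imidazol-2-yl ring as well. Thiophen-2-yl and 1H-pyrrol-3-yl are each one five-membered aromatic ring with the same count of heavy atoms and of hetero atoms, so those counts alone do not fix the number, and a hydrogen on a ring nitrogen does not fix it either, as compound 2 carries one and still stands level with compound 3. Nothing shown here gives a reason for these differences.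

Still open, as far as these compounds go, is whether a furan-3-yl ring, or a 1-methyl-1H-pyrrol-3-yl ring with a methyl group on the ring nitrogen, would stay with compound 4 or move to the level of compound 3. Also open, from the compounds shown here alone, is whether the same order of rings would hold if the 3,4-difluorobenzyl group of the shared core gave way to a plain benzyl group.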